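From compound 3 to compound 4 in a growth assay

The compounds below may be only part of what the source reports. "The series", "measured", "known", "first", "only" and "open" are said of these compounds alone.

Testing in a functional assay on NCI-H520 cells (Homo sapiens) for cytotoxicity (a higher number here means a weaker inhibitor of growth, a lower number a stronger inhibitor of growth), covers three compounds so far. Compound 1 (`COc1ccc(C2=C(c3cc(OC)c(OC)c(OC)c3)CC3CCCN3C2=O)cc1O`), which carries a free hydroxyl on one phenyl group, gives > 100000 nM here, which is a limit of the assay and not a number. Compound 2 (`COc1ccc(C2=C(c3ccc(SC)cc3)CC3CCCN3C2=O)cc1OC(=O)C1CCCN1C(=O)OC(C)(C)C`) gives 5000 nM in this read-out, while compound 3 (`COc1ccc(C2=C(c3ccc(SC)cc3)CC3CCCN3C2=O)cc1Br`) gives 700 nM as the lowest actual number, and its gap to compound 2 lies beyond the scatter.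

Compound 4 (`CSc1ccc(C2=C(c3ccc(O)cc3)C(=O)N3CCCC3C2)cc1`) has 4-hydroxyphenyl in place of 3-bromo-4-methoxyphenyl on a double-bonded ring carbon, next to the ring atom that bears a 4-(methylsulfanyl)phenyl group. For the measured compounds named here, no pair of measured compounds isolates this exchange, so the forecast is tentative and leans on compound 3 alone as the starting point. The expected change is a 5.7-fold higher number from compound 3 to compound 4 (0.76 log units; beyond the scatter) as a move toward weaker growth inhibition, beyond the scatter. For compound 4 the estimate is 4000 nM with an expected range from 700 nM to 30000 nM in this assay once it is measured.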

Compound 4, concentration for 50% growth inhibition: > 100000 nM
Compound 4: a limit, no number; the forecaster's own chance of this, stated with the estimate: 15%; middle value at least 25-fold (1.39 log units) away from the limit.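

Exchanging 3-bromo-4-methoxyphenyl for 4-hydroxyphenyl on the double-bonded ring carbon gives an at least 140-fold higher number from compound 3 to compound 4 (2.15 log units; beyond the scatter) in this assay and shows that, with the 4-(methylsulfanyl)phenyl group kept, the group at this position can by itself decide whether a number can be read at all. Compound 4 stands at > 100000 nM as a limit of the assay and not a number. The step is therefore a lower bound, and its full size cannot be read: the limit of > 100000 nM in this assay, at which 2 of the 4 values shown sit.

The exchange removes the bromine and also replaces the methoxy group with a hydroxyl, and the compounds shown do not separate these two changes. They leave open how a 4-methoxyphenyl or a 3-bromo-4-hydroxyphenyl group would read at this position.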